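Aromatic amide swap on the sulfonylurea series

This account rests on a few compounds, and the source may have more. Where it says the series, first, only, none or still open, it means among the compounds named here.

Measured so far:
compound 1 `Cn1cc(C(=O)NCCC2CCN(S(=O)(=O)NC(=O)NC3CCCCC3)CC2)c(=O)n(C)c1=O` 15%
compound 2 `COc1ccc(C(=O)NCCC2CCN(S(=O)(=O)NC(=O)NC[C@@H]3C[C@@H]4C=C[C@@H]3C4)CC2)cn1` 32%
compound 3 `Cn1cccc(C(=O)NCCC2CCN(S(=O)(=O)NC(=O)NC[C@@H]3C[C@@H]4C=C[C@@H]3C4)CC2)c1=O` 40%

In a functional assay on the whole organism (blood) with Rattus norvegicus as the target, with stated times of 24 h and 1 h, at a dose of 15 mg/kg by the intraperitoneal route (on this read-out lower numbers stand for a weaker effect and higher numbers for a stronger effect at the one dose given), compound 3 gives the highest of the three numbers; compound 2 sits within the scatter of it, compound 1 lies beyond the scatter below it. Compound 4 `Cn1cc(C(=O)NCCC2CCN(S(=O)(=O)NC(=O)NC[C@@H]3C[C@@H]4C=C[C@@H]3C4)CC2)c(=O)n(C)c1=O` differs from compound 3 by a group of 10 heavy atoms (6 carbon, 2 nitrogen, 2 oxygen; one six-membered aromatic ring with 2 hetero atoms) in place of a group of 8 heavy atoms (6 carbon, 1 nitrogen, 1 oxygen; one six-membered aromatic ring with 1 hetero atom), on a carbonyl carbon. Going by the values given here, the one step on this carbonyl carbon, a number 8 percentage points higher from compound 2 to compound 3 (within the scatter), stayed within the scatter, so an aromatic swap at this place has so far moved little. Compound 1 carries the same entering group with a different urea substituent and gives 15%, which argues for some loss. The expected step of a number 12 percentage points lower from compound 3 to compound 4 (beyond the scatter) is therefore a modest decrease, within or just beyond the scatter. Compound 4 is estimated at 28%, with a range from 10% to 45%.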

Compound 4, a percentage reported as activity, at one dose (the size of the read-out at that dose, not a potency): 32%
Estimate against measurement, compound 4: 4 percentage points below, within the range that was stated.
By their numbers in this assay, from the lowest: compound 1; then compounds 2, 4 and 3 (each within the scatter of the next).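

In this assay the swap on the carbonyl carbon gives a number 8 percentage points lower from compound 3 to compound 4 (within the scatter) and no change at the digits printed from compound 2 to compound 4 (within the scatter) so the three aromatic groups at this place cannot be told apart. Going by these compounds alone, the only step beyond the scatter lies on the amide-type nitrogen instead: a number 17 percentage points higher from compound 1 to compound 4 (beyond the scatter) with the aromatic group on the carbonyl carbon held constant. No measurement shown accounts for either result.

On these data alone, it remains open whether a non-aromatic group on this carbonyl carbon, such as an amine or a carboxylic acid, would hold the number. A longer chain on the amide-type nitrogen is also an open case.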